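A Second Fluoro on Compound 2

The source may hold more compounds than are shown below. What is called first, only, known or untested is meant among the compounds shown, and "the series" means these compounds.

In a functional assay on MCF-10A cells (Homo sapiens) for antiproliferative activity, with a stated time of 48 h (a lower number here means that less compound is needed, a higher number that more compound is needed for the effect), compound 1 (`COc1ccc2nc(C)cc(NCc3ccccc3)c2c1`) gives 25900 nM, compound 2 (`COc1ccc2nc(C)cc(NCc3cccc(F)c3)c2c1`) gives 11300 nM and compound 3 (`COc1ccc2nc(C)cc(NCc3ccccc3F)c2c1`) gives 14000 nM. Compound 2 stands clearly apart only from compound 1, with a 2.3-fold lower number from compound 1 to compound 2 (0.36 log units; beyond the scatter). It cannot be separated from its isomer, as the data show a 1.2-fold higher number from compound 2 to compound 3 (0.09 log units; within the scatter).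

Compound 4 (`COc1ccc2nc(C)cc(NCc3ccc(F)c(F)c3)c2c1`) has not yet been measured. It differs from compound 2 by one change, fluoro in place of hydrogen on an aromatic carbon, ortho to a fluoro group and para to a large group.

Two measured steps are of this same kind, both starting from the compound without fluoro. One is the step already given for compound 2, and the other is a 1.9-fold lower number from compound 1 to compound 3 (0.27 log units; within the scatter). Both are small and point the same way, though only the first lies beyond the scatter. Going by the values given here, no measured compound carries two fluoro groups, so whether a second one repeats this effect remains untested.

Going by a 2.3-fold lower number from compound 1 to compound 2 (0.36 log units; beyond the scatter), a small further move toward a lower number is expected, and it may not clear the scatter. The expected change is a 1.4-fold lower number from compound 2 to compound 4 (0.15 log units; within the scatter). For compound 4 the estimated value is 8000 nM, within an expected range of 3500 nM to 17000 nM.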

Compound 4, half-maximal effective concentration: 9100 nM
Estimate against measurement, compound 4: 1.1-fold (0.06 log units) below; measured number inside the range.
By their numbers in this assay, from the lowest: compounds 4, 2, 3 and 1 (each within the scatter of the next, the first and the last beyond it).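

In this assay, going by these compounds alone, a fluoro placed on the ring that already carries one, ortho to a fluoro group and para to a large group, gives a 1.2-fold lower number from compound 2 to compound 4 (0.09 log units; within the scatter), so this is the first reading of a second fluoro, and it cannot be separated from the compound with one. Within the data shown here, what the earlier compounds could not show is that a fluoro at this position, on a ring already bearing a fluoro, leaves the number within the scatter of its parent. The change has now also been read from two different starting compounds, and the two readings cannot be told apart: the same change on two cores in this assay, a 1.9-fold lower number (0.27 log units; within the scatter) from compound 1 to compound 3 and a 1.2-fold lower number (0.09 log units; within the scatter) from compound 2 to compound 4, 1.5-fold (0.17 log units) apart, within the scatter of two such steps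

The compounds shown include no ring with a fluoro at this position alone, so it stays open whether the fluoro here would read differently without the first one. As far as these compounds go, it also stays open whether a different group at this position, such as a chloro, a methoxy, an amine or a carboxylic acid, would give a step that clears the scatter.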